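From a Chlorophenyl Tail to an Aminophenyl Tail

The source may hold more compounds than are shown below. What is called first, only, known or untested is meant among the compounds shown, and "the series" means these compounds.

Compound 1, `O=C(CCCCCCc1ccccc1C(=O)O)c1ncc(-c2ccccn2)o1`, in an assay for inhibition of Fatty-acid amide hydrolase 1 (Rattus norvegicus) (a lower number here means a stronger inhibitor, a higher number a weaker inhibitor), gives > 600 nM; this is a limit of the assay, not a number.
Compound 2, `O=C(CCCCCCc1cccnc1)c1ncc(-c2ccccn2)o1`, gives 32 nM.
Compound 3, `O=C(CCCCCCc1ccc(Cl)cc1)c1ncc(-c2ccccn2)o1`, gives 2.7 nM.

Compound 3 holds the lowest of the two real numbers in this assay; the next one belongs to compound 2, separated by a 12-fold lower number from compound 2 to compound 3 (1.07 log units; beyond the scatter). Compound 1 sits at the limit (the limit of > 600 nM in this assay, at which 1 of the 3 values shown sits), so the step of an at least 220-fold lower number from compound 1 to compound 3 (2.34 log units; beyond the scatter) is known only as a floor, as is an at least 18-fold lower number from compound 1 to compound 2 (1.27 log units; beyond the scatter).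

The unmeasured compound 4, `Nc1cccc(CCCCCCC(=O)c2ncc(-c3ccccn3)o2)c1`, differs from compound 3 in one place: 3-aminophenyl in place of 4-chlorophenyl on a saturated chain carbon, six bonds along the chain from a carbonyl carbon. Both measured steps leaving compound 3 point the same way: swapping the 4-chlorophenyl for a ring carrying a heteroatom within it or an acid on it gave higher numbers, large in each case. The 3-aminophenyl brings one hydrogen-bond donor and one acceptor where the 4-chlorophenyl has none, which resembles the direction of the change from compound 3 to compound 2 more than anything else shown. A large upward step is therefore expected in this assay.

Compound 4 is estimated at 30 nM, with a range of 8 nM to 120 nM, meaning an expected step of an 11-fold higher number from compound 3 to compound 4 (1.05 log units; beyond the scatter).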

Compound 4, inhibition constant: 30 nM
The estimate for compound 4 equals the measured number at the digits printed; the measured number falls inside the stated range.
By their numbers in this assay, from the lowest: compound 3; then compounds 4 and 2 (each within the scatter of the next). At a limit, above all of these: compound 1.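

Compound 4 keeps a ring of carbon only with no net charge, yet in this assay the swap of 4-chlorophenyl for 3-aminophenyl, on a saturated chain carbon six bonds along the chain from a carbonyl carbon, still gives an 11-fold higher number from compound 3 to compound 4 (1.05 log units; beyond the scatter), so a large loss at this position does not need a nitrogen within the ring or a carboxylic acid on it. The step of a 1.1-fold lower number from compound 2 to compound 4 (0.03 log units; within the scatter) means that the pyridin-3-yl and 3-aminophenyl tails cannot be told apart in this assay, and the 4-chlorophenyl of compound 3 remains the only tail shown with a number clearly lower than both. The step of an at least 20-fold lower number from compound 1 to compound 4 (1.30 log units; beyond the scatter) extends the gap to the 2-carboxyphenyl tail but is known only as a floor, since compound 1 stands at a limit: the limit of > 600 nM in this assay, at which 1 of the 4 values shown sits.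

The compounds shown do not separate the exchange of chlorine for an amine from the change in where the group sits on the ring, and a 4-aminophenyl or a 3-chlorophenyl tail would divide the two. They also leave open how an unsubstituted phenyl tail would compare, and whether a shorter or longer chain would keep the same order among these tails.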